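Phenyl for methyl on a longer-chain analogue

The source may report more compounds than this note shows. Statements on the series, on what has been measured and on what is new or still open speak of the compounds shown alone.

The shared core carries a thioamide-terminated chain on one ring nitrogen and a small group on an aromatic carbon. Compound 1 `N=C(S)CCn1nc(-c2ccccc2)ccc1=S` bears a phenyl there; compound 2 `Cc1ccc(=S)n(CCC(=N)S)n1` bears a methyl. In a functional assay on the whole organism (stomach) for inhibition, with Rattus norvegicus as the target, at a dose of 100 mg/kg by the intraduodenal route (a lower number here means less inhibition, a higher number more inhibition at the dose given (going by the name of the read-out)), compound 1 gives 62.3%, and compound 2 gives 48.5%. The change between them, (phenyl in place of methyl on an aromatic carbon), made a step of a number 13.8 percentage points higher from compound 2 to compound 1 (beyond the scatter). Compound 3 `Cc1ccc(=O)n(CCCCCCC(=N)S)n1` has a longer chain and a carbonyl in place of the thione; the difference between its core and that of compound 2 is not broken down here. In this assay compound 3 gives 29.5%, the lowest of the three numbers.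

Compound 4 `N=C(S)CCCCCCn1nc(-c2ccccc2)ccc1=O` is not yet measured. It differs from compound 3 by phenyl in place of methyl on an aromatic carbon. This is the same kind of change as from compound 2 to compound 1, though the surroundings differ: in compound 1 the place is meta to a group of 5 heavy atoms, in compound 4 it is meta to a group of 9 heavy atoms. Among the compounds with values here, only one earlier instance of this change exists, on a different core, so the expectation rests on that single step.

For compound 4 a step of about a number 13.5 percentage points higher from compound 3 to compound 4 (beyond the scatter) is expected, carried over from the earlier step because of a number 13.8 percentage points higher from compound 2 to compound 1 (beyond the scatter) seen in compound 1. The estimate for compound 4 in this assay is therefore 43%, with a range from 30% to 58%.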

Compound 4, a percentage reported as inhibition, in the whole organism at one dose (the size of the read-out at that dose, not a potency): 33.9%
Compound 4: the middle estimate sits 9.1 percentage points above what was measured; low and high end bracket the measured number.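

On the longer-chain core, phenyl in place of methyl on an aromatic carbon gives, in this assay, a number 4.4 percentage points higher from compound 3 to compound 4 (within the scatter), so on this core the change has no effect that can be told from the usual spread of repeats. Set beside the step on the shorter-chain core, a number 13.8 percentage points higher from compound 2 to compound 1 (beyond the scatter), the new step does not differ from it by more than two such steps can scatter: the same change on two cores in this assay, a number 13.8 percentage points higher (beyond the scatter) from compound 2 to compound 1 and a number 4.4 percentage points higher (within the scatter) from compound 3 to compound 4, 9.4 percentage points apart, within the scatter of two such steps This shows that the series gives no firm sign of the core altering the change, but it does not show that the change carries over unaltered, since one step lies beyond the scatter, the other within it, and two instances are too few to fix a typical size.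

The two cores differ both in chain length and in carbonyl against thione, and no pair shown alters one of these alone, so it remains open whether either bears on the size of the step. Also open, on these data alone, is how the series responds to a chain of intermediate length, to an amine or a carboxylic acid in place of the thioamide end, or to a methoxy group in place of phenyl on that aromatic carbon.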